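The source may report more compounds than this note shows. Statements on the series, on what has been measured and on what is new or still open speak of the compounds shown alone.

In a functional assay on NCI-H3122 cells (Homo sapiens) for antiproliferative activity, read by MTT assay, with a stated time of 48 h (on this read-out lower numbers stand for stronger inhibition and higher numbers for weaker inhibition), three compounds have been measured:

- compound 1 `CC(Oc1ccnc(Nc2cnn(C3CCN(C)CC3)c2)c1)c1cccc(C(=O)NCc2ccc(Cl)c(C(F)(F)F)c2)c1`: 8000 nM
- compound 2 `Cc1ccc(CNC(=O)c2cccc(C(C)Oc3ccnc(Nc4cn(C)nc4C)c3)c2)cc1`: 13400 nM
- compound 3 `Cc1ccc(CNC(=O)c2cccc(C(C)Oc3ccnc(NN4CCN(C)CC4)c3)c2)cc1`: 8100 nM

Compound 3 stands with the other two, and its value lies within the scatter of both. The three values therefore show no separation in this assay.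

The next compound is compound 4 `CC(Oc1ccnc(NN2CCN(C)CC2)c1)c1cccc(C(=O)NCc2ccc(Cl)c(C(F)(F)F)c2)c1`, which differs from compound 3 at a single place: 4-chloro-3-(trifluoromethyl)phenyl in place of 4-methylphenyl on a saturated chain carbon bound to an amide-type nitrogen. Put another way, 4-chloro-3-(trifluoromethyl)benzyl replaces 4-methylbenzyl. Going by the values given here, no measured step covers this exchange. Among the compounds with values here, the only step available, a 1.7-fold lower number from compound 2 to compound 3 (0.22 log units; within the scatter), changes a different place and offers no direct guide to its size. The closest evidence is compound 1, which carries the same 4-chloro-3-(trifluoromethyl)phenyl group as the new compound and gives 8000 nM. Compound 1 also differs from compound 4 in the group on the aromatic amine nitrogen, so this is only indirect support. Nothing here points to a clear shift in either direction, so no change beyond the scatter is expected. The expected step is a 1.2-fold lower number from compound 3 to compound 4 (0.06 log units; within the scatter). For compound 4 the estimated value is 7000 nM, with an expected range of 2500 nM to 16000 nM.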

Compound 4, half-maximal inhibitory concentration: 21700 nM
Estimate against measurement, compound 4: 3.1-fold (0.49 log units) below; the whole stated range lies below it.
By their numbers in this assay, from the lowest: compounds 1, 3, 2 and 4 (each within the scatter of the next, the first and the last beyond it).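

In this assay, going by these compounds alone, the result shows for the first time that the aryl group on the saturated chain carbon bound to an amide-type nitrogen affects the read-out: with the 4-methylpiperazin-1-yl group held constant, 4-chloro-3-(trifluoromethyl)phenyl in place of 4-methylphenyl gives a 2.7-fold higher number from compound 3 to compound 4 (0.43 log units; beyond the scatter) and so a modest loss of inhibition. With 4-chloro-3-(trifluoromethyl)phenyl held constant, the group on the nitrogen on the aromatic ring also matters, as 4-methylpiperazin-1-yl in place of 1-(1-methylpiperidin-4-yl)-1H-pyrazol-4-yl gives a 2.7-fold higher number from compound 1 to compound 4 (0.43 log units; beyond the scatter) while the earlier exchange at that place, which starts from a different pyrazole and carries 4-methylphenyl, gave only a 1.7-fold lower number from compound 2 to compound 3 (0.22 log units; within the scatter) and stayed within the scatter. Nothing available explains either of the new steps.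

As far as these compounds go, what remains open is whether the loss follows the chlorine, the trifluoromethyl or the two together, which an unsubstituted phenyl or a phenyl carrying chlorine alone at this place would help to separate. It is also open whether the aryl exchange would have the same size on the pyrazole-bearing compounds, since only one such pair is shown here, with the 4-methylpiperazin-1-yl group.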